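A larger amide substituent tested on the strongest compound

The source may hold more compounds than are shown below. What is called first, only, known or untested is meant among the compounds shown, and "the series" means these compounds.

Compound 2 `CC[C@@H]1C(=O)N(C)c2cnc(-n3ccc4cc(C(=O)NC(C)C)ccc43)nc2N1C1CCCC1` stands at the lowest number of the three measured compounds: in an assay for inhibition of serine/threonine-protein kinase PLK2 (Homo sapiens), read by FRET and Z'-LYTE, with a stated time of 1 h (on this read-out lower numbers stand for stronger inhibition and higher numbers for weaker inhibition), compound 2 gives 17.4 nM, whereas compound 1 `CCC1C(=O)N(C)c2cnc(-n3ccc4cc(C(=O)NC(C)C)ccc43)nc2N1c1ccn(C)n1` gives 125 nM and compound 3 `CCC1C(=O)N(C)c2cnc(-n3ccc4cc(C(=O)NCC(C)C)ccc43)nc2N1c1ccn(C)n1` gives 159 nM, both beyond the scatter from compound 2. Compound 4 `CC[C@@H]1C(=O)N(C)c2cnc(-n3ccc4cc(C(=O)NC5CCCC5)ccc43)nc2N1C1CCCC1` differs from compound 2 by cyclopentyl in place of isopropyl on an amide-type nitrogen. For the measured compounds named here, the only measured step at the same place is a 1.3-fold higher number from compound 1 to compound 3 (0.10 log units; within the scatter), which stayed within the scatter. On that basis no movement beyond the scatter is expected for compound 4 in this assay, with the step of a 1.1-fold higher number from compound 2 to compound 4 (0.06 log units; within the scatter) expected to be small in either direction. Compound 4 is therefore expected to give 20 nM, within a range of 8 nM to 50 nM.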

Compound 4, half-maximal inhibitory concentration: 7.06 nM
For compound 4 the middle estimate is 2.8-fold (0.45 log units) above the measured one, outside the stated range (below it).
By their numbers in this assay, from the lowest: compound 4; then compound 2; then compounds 1 and 3 (each within the scatter of the next).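

Cyclopentyl in place of isopropyl on the amide-type nitrogen gives a 2.5-fold lower number from compound 2 to compound 4 (0.39 log units; beyond the scatter) in this assay and so moves the number beyond the scatter. The earlier change at this nitrogen, a 1.3-fold higher number from compound 1 to compound 3 (0.10 log units; within the scatter), did not, so the position is not indifferent to its substituent, at least with the cyclopentyl-bearing compound 2 as the parent. Nothing available explains this step.

On these data alone, whether the ring or simply the added carbon atoms matter remains open, as does the effect of cyclopentyl on compound 1. A cyclohexyl group, or a ring carrying an amine, could show how far this trend extends.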